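The source may hold more compounds than are shown below. What is called first, only, known or untested is meant among the compounds shown, and "the series" means these compounds.

Compound 3 `CC(C)=CCC(=O)C1(O)C(O)=C(C(C)C)C(=O)C1CC=C(C)C` gives 2.05 in a physicochemical assay for lipophilicity, measured as octanol-water partition (on this read-out higher numbers stand for higher lipophilicity and lower numbers for lower lipophilicity), and stands lowest of the three values measured; compound 1 `CC(C)=CCC1=C(O)C(C(=O)C(C)C)=C(O)[C@](O)(CC=C(C)C)C1=O` lies nearest with 2.92, and compound 2 `CC(C)=CCC1=C(O)C(C(=O)CC(C)C)=C(O)[C@](O)(CC=C(C)C)C1=O` lies furthest with 3.01. Compound 4 `CC(C)=CCC(=O)C1(O)C(O)=C(C(C)C(C)C)C(=O)C1CC=C(C)C` is the next one to be measured in this assay. It differs from compound 3 in one place: isopropyl in place of methyl on a saturated chain carbon bound to a double-bonded ring carbon and a saturated chain carbon. Among the measured compounds shown here, only one measured step bears on this change, the one where a carbon is added to a chain, a number 0.09 log units higher from compound 1 to compound 2 (within the scatter), and that step stayed within the scatter. For the measured compounds named here, the change to compound 4 adds more carbon than that step did, so a rise in this assay is expected, though the one measured step argues that it need not be large. Compound 4 is therefore estimated at 2.65, with a range from 2.2 to 3.1. The expected step is a number 0.60 log units higher from compound 3 to compound 4 (beyond the scatter), an increase that would still leave compound 4 at or below the values of compound 1 and compound 2.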

Compound 4, partition coefficient: 2.53
Estimate against measurement, compound 4: 0.12 log units above; measured number inside the range.
By their numbers in this assay, from the lowest: compound 3; then compound 4; then compounds 1 and 2 (each within the scatter of the next).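

In this assay, among the compounds shown here, replacing methyl with isopropyl at this place gives a clear move, a number 0.48 log units higher from compound 3 to compound 4 (beyond the scatter), whereas the only earlier step that added carbon, a number 0.09 log units higher from compound 1 to compound 2 (within the scatter), made on a carbonyl carbon of a different core, stayed within the scatter. This shows that the read-out responds to a change on this saturated chain carbon, though the finding rests on a single pair on a single core. No measurement at hand accounts for the size of this step.

The compounds shown leave open whether a longer chain such as n-butyl at this place would extend the rise, and what a hydroxyl or an amine there would do to the number. They also leave open whether the same swap of methyl for isopropyl would give a similar step on the core of compound 1.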